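Lengthening the side chain of a thiocarbamate lactone

The compounds below may be only part of what the source reports. "The series", "measured", "known", "first", "only" and "open" are said of these compounds alone.

compound 1, `CCCCSC(=S)N[C@H]1CCOC1=O`, in a functional assay on MGC-803 cells (Homo sapiens) for cytotoxicity, read by MTT assay, with a stated time of 72 h; on this read-out higher numbers stand for weaker inhibition and lower numbers for stronger inhibition: > 128000 nM, a limit of the assay
compound 2, `CCCCCCSC(=S)N[C@H]1CCOC1=O`, in this assay: > 128000 nM, a limit of the assay

Compound 2 gives only a limit in this assay, so its place among the numbers shown cannot be fixed. Compound 3, `CCCCCCCCSC(=S)N[C@H]1CCOC1=O`, differs from compound 2 by ethyl in place of hydrogen on a saturated chain carbon, six bonds along the chain from a sulfur. Going by the values given here, the one measured step that bears on this change is a step that the two limits leave unreadable from compound 1 to compound 2, with both values at the limit of > 128000 nM in this assay, at which 2 of the 2 values shown sit; it yields no readable size and no direction beyond the scatter. For compound 3 the expected result is 128000 nM, with a range from 40000 nM to 400000 nM, most likely again only a limit. The implied step a number no higher from compound 2 to compound 3 (the limit leaves the size open) is expected to be none beyond the scatter.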

Compound 3, half-maximal inhibitory concentration: > 128000 nM
Compound 3 was reported as a limit (the forecaster's own chance of this, stated with the estimate: 75%); the middle value sits exactly at the limit.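

Compound 1, compound 2 and compound 3 all end at a limit of the assay, so no step among them can be read: the limit of > 128000 nM in this assay, at which 3 of the 3 values shown sit.

Going by these compounds, the true potency of each, and whether the chain length changes it at all, stays open.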